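Carbamoyl to methoxy on the aryl piperazine series

The compounds below may be only part of what the source reports. "The series", "measured", "known", "first", "only" and "open" are said of these compounds alone.

Measured in a functional assay on HL-60 cells (Homo sapiens) for inhibition, read by MTT assay, with a stated time of 72 h; a lower number here means a stronger inhibitor, a higher number a weaker inhibitor:
- compound 1 `Cc1nc(-c2ccc(F)cc2)c(C(=O)N2CCN(c3ccc(C(=O)C(C)C)cc3)CC2)o1` gives "not active" (no number reported)
- compound 2 `Cc1nc(-c2ccccc2)c(C(=O)N2CCN(c3cccc(C(N)=O)c3)CC2)o1` gives 71 nM
- compound 3 `Cc1nc(-c2ccccc2Cl)c(C(=O)N2CCN(c3cccc(Cl)c3)CC2)o1` gives 132 nM

Compound 2 at 71 nM and compound 3 at 132 nM lie within the scatter of each other, and compound 1 gives no number to set against them. Compound 4 `COc1cccc(N2CCN(C(=O)c3oc(C)nc3-c3ccccc3)CC2)c1` has methoxy in place of carbamoyl on an aromatic carbon, meta to a large group (methoxy in place of carbamoyl on an aromatic carbon). Within the data shown here, no measured step between two compounds is available to size this change. In this assay the expected step is small and towards a higher number: a 1.8-fold higher number from compound 2 to compound 4 (0.26 log units; within the scatter). The range is kept wide, and a result without a number, as for compound 1, cannot be excluded. In this assay, compound 4 is estimated at 130 nM, with an expected range of 35 nM to 500 nM.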

Compound 4, half-maximal inhibitory concentration: 34.8 nM
Compound 4: middle estimate off by 3.7-fold (0.57 log units), on the high side, and the stated range ends above it.
By their numbers in this assay, from the lowest: compound 4; then compounds 2 and 3 (each within the scatter of the next).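

In this assay, replacing carbamoyl with methoxy on this aromatic carbon, meta to a large group, gives a 2.0-fold lower number from compound 2 to compound 4 (0.31 log units; beyond the scatter). Among these compounds, this is the first sized change at this position: the step is modest, and the hydrogen-bond donor of carbamoyl is not required for inhibition. No measurement here bears on why the number falls.

As far as these compounds go, whether a hydroxyl, an amine or the longer ethoxy at this position would go further remains open. Also open, from the compounds shown here alone, is whether the step carries over to the core of compound 3.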